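This account rests on a few compounds, and the source may have more. Where it says the series, first, only, none or still open, it means among the compounds named here.

Compound 3 `c1ccc(Nc2nc(-c3nc4ccccc4s3)cs2)nc1` gives 6700 nM in a functional assay on PC-3 cells (Homo sapiens) for inhibition (a lower number here means a stronger inhibitor, a higher number a weaker inhibitor), the highest of the three numbers in hand. For the measured compounds named here, compound 1 `CCn1c(=O)/c(=C2\Sc3cc(F)ccc3N2C)s/c1=C\c1ccncc1Nc1ccccc1Cl` gives 1200 nM and compound 2 `CCn1c(=O)/c(=C2\Sc3cc(F)ccc3N2C)s/c1=C\c1ccncc1Nc1ccccc1F` gives 260 nM, both on a core unrelated to that of compound 3; the only step measured within a matched pair, a 4.6-fold lower number from compound 1 to compound 2 (0.66 log units; beyond the scatter), concerns a halogen swap on that other core and says nothing about the change considered here.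

Compound 4 `c1ccc(Nc2nc(-c3nc4ccccc4s3)cs2)cc1` is the unmeasured partner of compound 3. The difference, (phenyl in place of pyridin-2-yl on a nitrogen on an aromatic ring), removes the one hydrogen-bond acceptor counted in the leaving group and keeps everything else of compound 3. Going by the values given here, no measured step bears on this exchange, and the shared core of compound 3 and compound 4 has a single number so far, so the direction of the step cannot be read from the data. The expectation is therefore a step of a 1.0-fold higher number from compound 3 to compound 4 (0.02 log units; within the scatter), not beyond the scatter, with wide uncertainty. Compound 4 is estimated at 7000 nM, between 2500 nM and 20000 nM.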

Compound 4, half-maximal inhibitory concentration: 5500 nM
The estimate for compound 4 lay 1.3-fold (0.10 log units) above the measured number, and the stated range covers the measured number.
By their numbers in this assay, from the lowest: compound 2; then compound 1; then compounds 4 and 3 (each within the scatter of the next).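

In this assay the exchange of pyridin-2-yl for phenyl on the nitrogen gives a 1.2-fold lower number from compound 3 to compound 4 (0.09 log units; within the scatter). On the shared core of compound 3 and compound 4, the hydrogen-bond acceptor counted in pyridin-2-yl can therefore be lost with no step beyond the scatter, a reading that the halogen swap on the core of compound 1 could not give. No separate measurement bears on why the two groups read alike.

Going by these compounds, it remains open whether this position stays within the scatter for groups of another kind, such as a cyclohexyl or a phenyl carrying a carboxylic acid or an amine. Also open, on these data alone, is whether a swap of chloro for fluoro on the phenyl of compound 4 would give any step like the one seen on the other core.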